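Swapping the amide substituent in a cytotoxicity series

This account rests on a few compounds, and the source may have more. Where it says the series, first, only, none or still open, it means among the compounds named here.

The measured compounds and their values:
- compound 1, `COc1cc2cc(N)c(=O)oc2cc1OCCCOc1no[n+]([O-])c1S(=O)(=O)c1ccccc1`, in an ADME assay on MCF-10A cells (Homo sapiens) for cytotoxicity, read by MTT assay, with a stated time of 48 h (a lower number here means a stronger inhibitor, a higher number a weaker inhibitor), compound 1 gives 6450 nM
- compound 2, `COc1cc2cc(C(=O)NCCCc3ccccc3)c(=O)oc2cc1OCCCOc1no[n+]([O-])c1S(=O)(=O)c1ccccc1`, in this assay compound 2 gives 5330 nM
- compound 3, `COc1ccc(CNC(=O)c2cc3cc(OC)c(OCCCOc4no[n+]([O-])c4S(=O)(=O)c4ccccc4)cc3oc2=O)cc1`, in this assay compound 3 gives 5950 nM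

Among these three numbers compound 2 has the lowest, but its neighbours lie close: a 1.1-fold higher number from compound 2 to compound 3 (0.05 log units; within the scatter) and, from the amino parent, a 1.2-fold lower number from compound 1 to compound 2 (0.08 log units; within the scatter), both within the scatter, as is a 1.1-fold lower number from compound 1 to compound 3 (0.04 log units; within the scatter). The three values therefore cannot be ordered.

Compound 4, `COc1cc2cc(C(=O)Nc3ccc(F)cc3)c(=O)oc2cc1OCCCOc1no[n+]([O-])c1S(=O)(=O)c1ccccc1`, is not yet measured. It differs from compound 2 in one place: 4-fluorophenyl in place of 3-phenylpropyl on an amide-type nitrogen. Among the compounds with values here, no measured pair makes this exact exchange, so no step speaks to it directly. What the measured steps do show is that changes at this amide-type nitrogen, and even replacing the whole carbamoyl group by amino, leave the number within the scatter. On that basis the step of a 1.1-fold higher number from compound 2 to compound 4 (0.04 log units; within the scatter) is expected to stay within the scatter as well. Compound 4 is estimated at 5800 nM, with a range from 2900 nM to 11600 nM.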

Compound 4, half-maximal inhibitory concentration: 7210 nM
Estimate against measurement, compound 4: 1.2-fold (0.09 log units) below; measured number inside the range.
By their numbers in this assay, from the lowest: compounds 2, 3, 1 and 4 (each within the scatter of the next).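

Compound 4 brings the first aromatic ring placed on the amide-type nitrogen without a saturated chain, as 4-fluorophenyl replaces the chain-bearing groups, and in this assay this exchange still gives only a 1.4-fold higher number from compound 2 to compound 4 (0.13 log units; within the scatter) and a 1.2-fold higher number from compound 3 to compound 4 (0.08 log units; within the scatter). Replacing the whole (4-fluorophenyl)carbamoyl group with amino tells the same story in reverse, with a 1.1-fold higher number from compound 1 to compound 4 (0.05 log units; within the scatter), so all four compounds remain within the scatter of the next and this position has so far shown no measurable effect on the number. No supporting evidence bears on why this exchange changes so little.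

As far as these compounds go, whether a carboxylic acid or an amine at the end of a longer chain on this nitrogen would shift the number remains open. All four compounds also keep the rest of the shared core, so they say nothing about changes there.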